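The compounds below may be only part of what the source reports. "The series", "measured", "known", "first", "only" and "open" are said of these compounds alone.

Of the compounds shown here, three sharing a core have been measured in a functional assay on the whole organism for inhibition, with Rattus norvegicus as the target, read by paw edema, with stated times of 1 h and 3 h; a higher number here means that more compound is needed for the effect, a lower number that less compound is needed. Compound 1 `C/C(=N\OCC(=O)O)c1ccc(C(F)(F)F)cc1` gives 120 mg/kg, compound 2 `COC(=O)CO/N=C(\C)c1ccc(Cl)cc1` gives 24 mg/kg, and compound 3 `COC(=O)CO/N=C(\C)c1ccc(Br)cc1` gives 14 mg/kg. Compound 2 therefore lies well below compound 1 on these numbers and within the scatter of compound 3.

The account now turns to compound 4 `C/C(=N\OCCC(=O)O)c1ccc(Cl)cc1`, which has the same atoms as compound 2, joined differently: carboxymethyl in place of methoxycarbonyl on a saturated chain carbon bound to an oxygen on an unsaturated carbon. In words, carboxymethyl stands in place of methoxycarbonyl on a saturated chain carbon bound to an oxygen on an unsaturated carbon.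

Among the measured compounds shown here, the only measured step, a 1.7-fold lower number from compound 2 to compound 3 (0.23 log units; within the scatter), is bromo in place of chloro on an aromatic carbon, so it does not test this chain change. It bears on the question only as a step that stayed within the scatter. The nearest evidence is compound 1 at 120 mg/kg, which also ends in a free carboxy group. However, it differs from compound 4 in its chain and in carrying trifluoromethyl rather than chloro, so its gap to compound 2 is only a loose guide.

A rise in the number beyond the scatter is therefore expected, with the estimated step being a 2.5-fold higher number from compound 2 to compound 4 (0.40 log units; beyond the scatter). For compound 4 the estimate is 60 mg/kg, with an expected range from 20 mg/kg to 170 mg/kg.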

Compound 4, dose for half-maximal effect: 80 mg/kg
For compound 4 the middle estimate is 1.3-fold (0.12 log units) below the measured one; measured number inside the range.
By their numbers in this assay, from the lowest: compounds 3 and 2 (each within the scatter of the next); then compounds 4 and 1 (each within the scatter of the next).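

In this assay, carboxymethyl in place of methoxycarbonyl on a saturated chain carbon bound to an oxygen on an unsaturated carbon gives a 3.3-fold higher number from compound 2 to compound 4 (0.52 log units; beyond the scatter), whereas the earlier step on an aromatic carbon, a 1.7-fold lower number from compound 2 to compound 3 (0.23 log units; within the scatter), stayed within the scatter. This position is thus the first shown at which a single change moves the number beyond the scatter, even though the two compounds hold the same atoms, and the entering group counts a hydrogen-bond donor where the leaving group counts none. No measurement shown here accounts for the rise.

The same difference also reads as (methoxycarbonyl)methyl to 2-carboxyethyl, so the compounds shown leave open whether the rise goes with the free carboxylic acid or with the rearranged chain. A methyl ester on the 2-carboxyethyl chain, a primary amide in place of the carboxylic acid, or a longer chain ending in a carboxylic acid, each with the chloro group kept, would separate these two readings.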